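From 4-bromophenyl to 4-chlorophenyl: working notes on the series

The source may report more compounds than this note shows. Statements on the series, on what has been measured and on what is new or still open speak of the compounds shown alone.

Among the measured compounds shown here, in a functional assay on MCF7 cells (Homo sapiens) for antiproliferative activity, read by MTT assay, with a stated time of 48 h (a higher number here means a weaker inhibitor, a lower number a stronger inhibitor), compound 1 (`O=C(/C=C/c1ccccc1)Nc1nnc(-c2ccccc2)s1`) gives 1.47 ug/mL and compound 2 (`O=C(/C=C/c1ccccc1)Nc1nnc(-c2ccc(Br)cc2)s1`) gives 1.5 ug/mL as the only other number so far. These two values lie within the scatter of each other, so compound 2 stands level with compound 1 and neither can be ranked.

Compound 3 (`O=C(/C=C/c1ccccc1)Nc1nnc(-c2ccc(Cl)cc2)s1`) follows from compound 2 by one change (chloro in place of bromo on an aromatic carbon), chloro in place of bromo on an aromatic carbon, para to a large group, that is, 4-bromophenyl to 4-chlorophenyl.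

For the measured compounds named here, one measured step bears on this: bromo in place of hydrogen on an aromatic carbon, which gave a 1.0-fold higher number from compound 1 to compound 2 (0.01 log units; within the scatter) as the only guide. Going by the values given here, no measured compound carries chloro yet, so the evidence is a single pair. In this assay no step beyond the scatter is therefore expected, and no direction can be called. The expected step is no change at the digits printed from compound 2 to compound 3 (within the scatter) by estimate, and it would not exceed the scatter. For compound 3 the expected value is 1.5 ug/mL (estimated range 0.8 ug/mL to 2.8 ug/mL).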

Compound 3, half-maximal inhibitory concentration: 1.42 ug/mL
Compound 3: middle estimate off by 1.1-fold (0.02 log units), on the high side; the range from low to high includes it.
By their numbers in this assay, from the lowest: compounds 3, 1 and 2 (each within the scatter of the next).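

With chloro now at this place, para to a large group, the halogen can be read against both neighbours in this assay: bromo to chloro gives (a 1.1-fold lower number from compound 2 to compound 3 (0.02 log units; within the scatter)), and hydrogen to chloro gives (a 1.0-fold lower number from compound 1 to compound 3 (0.02 log units; within the scatter)). The earlier pair covered bromo alone, whereas these three compounds show that hydrogen, bromo and chloro at this place cannot be separated from one another, since each step lies within the scatter. This flat reading holds only for these three compounds, and no measured property bears on it, leaving no basis for an explanation.

From the compounds shown here alone, whether any group at this place can move the number beyond the scatter remains open, as an amine, a methoxy group or a carboxylic acid there would test a different kind of substituent from the two halogens. Also open, going by these compounds, is whether this assay would read the same for chloro or bromo elsewhere on this six-membered aromatic ring, or for a change elsewhere in the shared core.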